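The compounds below may be only part of what the source reports. "The series", "measured", "known", "first", "only" and "open" are said of these compounds alone.

Measured compounds:
Compound 1 `COc1ccc(-c2ccc(CNCCNc3ccnc4cc(Cl)ccc34)s2)cc1` gives 3130 nM in an ADME assay on HepG2 cells (Homo sapiens) for cytotoxicity, read by MTT assay, with a stated time of 48 h; on this read-out higher numbers stand for weaker inhibition and lower numbers for stronger inhibition.
Compound 2 `CC(=O)Nc1ccc(-c2ccc(CNCCCNc3ccnc4cc(Cl)ccc34)s2)cc1` gives 2080 nM in this assay.

Compound 2 carries the lowest of the two numbers shown, yet its only neighbour, compound 1, lies within the scatter of it, so the two cannot be placed in order. Compound 3 `Clc1ccc2c(NCCCNCc3ccc(-c4cccnc4)s3)ccnc2c1` has not been measured in this assay. It differs from compound 2 in a single place: pyridin-3-yl in place of 4-acetamidophenyl on an aromatic carbon. Within the data shown here, no step between measured compounds addresses a change of this kind, and the two values known say nothing about an exchange at that carbon. The expectation for compound 3 in this assay is therefore a small step from compound 2, if any, no larger than the scatter and tending toward a higher number. Compound 3 is expected to give about 2600 nM in this assay, between 1200 nM and 6000 nM, which would mean a step of a 1.3-fold higher number from compound 2 to compound 3 (0.10 log units; within the scatter).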

Compound 3, half-maximal inhibitory concentration: 21600 nM
Beside the measured number, compound 3's estimate is 8.3-fold (0.92 log units) below it; the measured number lies above the stated range.
By their numbers in this assay, from the lowest: compounds 2 and 1 (each within the scatter of the next); then compound 3.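

In this assay, the aromatic carbon next to the ring sulfur proves sensitive to the group it carries: pyridin-3-yl in place of 4-acetamidophenyl gives a 10-fold higher number from compound 2 to compound 3 (1.02 log units; beyond the scatter). Compound 1 and compound 2 differ in more than one place, so they could not show this. The exchange replaces the larger group and removes its hydrogen-bond donor while bringing a nitrogen into the six-membered aromatic ring, so these differences cannot be separated, and nothing available explains the step.

Going by these compounds, it remains open whether a plain phenyl, a 4-aminophenyl or a pyridin-4-yl group on this carbon would give a number nearer that of compound 2 or compound 3. On these data alone, it is also open whether the same exchange would have a similar effect on a core with a longer chain.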